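This account rests on a few compounds, and the source may have more. Where it says the series, first, only, none or still open, it means among the compounds named here.

In a functional assay on HepG2 cells (Homo sapiens) for inhibition, read by MTT assay, with a stated time of 72 h (on this read-out lower numbers stand for stronger inhibition and higher numbers for weaker inhibition), compound 1 `CC(C)n1ncc2c(C(=O)NCc3cn(-c4ccccc4)nn3)cccc21` gives > 40000 nM, which is a limit of the assay and not a number. In this assay compound 2 `Cc1ccc(-n2cc(CNC(=O)c3cccc4c3cnn4C(C)C)nn2)cc1C` gives > 40000 nM, again a limit. In this assay compound 3 `CC(C)n1ncc2c(C(=O)NCc3cn(-c4ccc(I)cc4)nn3)cccc21` gives > 40000 nM, also a limit.

Compound 3 therefore stands where every value shown stands: at the limit of > 40000 nM in this assay, at which 3 of the 3 values shown sit. None of the three compounds is told apart from the others. The step from compound 1 to compound 2 is a step that the two limits leave unreadable from compound 1 to compound 2; the step from compound 1 to compound 3 is a step that the two limits leave unreadable from compound 1 to compound 3; the step from compound 2 to compound 3 is a step that the two limits leave unreadable from compound 2 to compound 3.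

Compound 4 `CC(C)n1ncc2c(C(=O)NCc3cn(-c4ccc(F)cc4)nn3)cccc21` differs from compound 3 in one place: fluoro in place of iodo on an aromatic carbon. Among the compounds with values here, the nearest measured step, the one from compound 1 to compound 3, swaps hydrogen for iodo at this same place, and its size cannot be read from two limits, so no measured step gives a size for the present change. With every shown value sitting at the limit, compound 4 is expected to sit there as well, and the step from compound 3 to compound 4 is expected to be a step that the limit leaves unreadable from compound 3 to compound 4. Compound 4 is estimated at 50000 nM in this assay, within a range from 15000 nM to 150000 nM.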

Compound 4, half-maximal inhibitory concentration: > 40000 nM
Compound 4 ended at the assay's limit; the forecaster's own chance of this, stated with the estimate: 85%; the middle value is on the limit's open side.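

No step can be read among compound 1, compound 2, compound 3 and compound 4, as each value is a limit and not a number: the limit of > 40000 nM in this assay, at which 4 of the 4 values shown sit.

The compounds shown leave open how far past that limit each one lies, and whether changing the group on the phenyl makes any difference at all in this assay.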